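The source may hold more compounds than are shown below. What is called first, only, known or untested is meant among the compounds shown, and "the series" means these compounds.

Measured compounds:
compound 1 `COc1ccc(-c2nc(N=C(N)N)sc2-c2ccc(OC)cc2)cc1` gives 31000 nM
compound 2 `C/N=C(/NC)Nc1nc(-c2ccc(OC)cc2)c(-c2ccc(OC)cc2)s1` gives 970 nM
compound 3 `COc1ccc(-c2nc(CNC(C)=O)sc2-c2ccc(OC)cc2)cc1` gives 15 nM

In a functional assay with Oryctolagus cuniculus as the target (on this read-out higher numbers stand for weaker inhibition and lower numbers for stronger inhibition), compound 3 stands lowest of the three, with compound 2 as its nearest neighbour and compound 1 furthest away. Compound 4 `COc1ccc(-c2nc(C3=NNC(=O)CC3)sc2-c2ccc(OC)cc2)cc1` differs from compound 3 by a group of 7 heavy atoms (4 carbon, 2 nitrogen, 1 oxygen; one six-membered non-aromatic ring with 2 hetero atoms) in place of a group of 5 heavy atoms (3 carbon, 1 nitrogen, 1 oxygen; no ring), on an aromatic carbon. Within the data shown here, the steps that bear on this change are a 2100-fold lower number from compound 1 to compound 3 (3.32 log units; beyond the scatter) and a 65-fold lower number from compound 2 to compound 3 (1.81 log units; beyond the scatter), together with a 32-fold lower number from compound 1 to compound 2 (1.50 log units; beyond the scatter): every exchange at this aromatic carbon has moved this assay by a large amount, so the position is sensitive, but neither step shows what a ring-bearing group does there. The entering group keeps a donor and adds an acceptor, so a moderate shift is expected, with the direction uncertain and a somewhat higher number the more probable case. Compound 4 is therefore estimated at 40 nM, within 8 nM to 250 nM, corresponding to an expected 2.7-fold higher number from compound 3 to compound 4 (0.43 log units; beyond the scatter).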

Compound 4, half-maximal inhibitory concentration: > 1000 nM
Compound 4 gave a limit, no number; the forecaster's own chance of this, stated with the estimate: 5%; middle value at least 25-fold (1.39 log units) away from the limit.
By their numbers in this assay, from the lowest: compound 3; then compound 2; then compound 1.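

In this assay compound 4 gives > 1000 nM, which is a limit of the assay and not a number. Putting the six-membered ring with 2 hetero atoms in place of acetamidomethyl gives an at least 66-fold higher number from compound 3 to compound 4 (1.82 log units; beyond the scatter), the first sign that a ring-bearing group on this aromatic carbon can give up the low number of compound 3. The limit says little beyond that, as an at least 1.0-fold higher number from compound 2 to compound 4 (0.01 log units; that floor lies within the scatter) sets no order between those two compounds, and the step from compound 1 cannot be read.

The compounds shown leave open whether the high number goes with the ring as such or with its hetero atoms. As far as these compounds go, how a plain piperidine ring or a longer amide chain would read on this carbon also remains open.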